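Anilide series: acetyl to propylbenzoyl step

The source may report more compounds than this note shows. Statements on the series, on what has been measured and on what is new or still open speak of the compounds shown alone.

Measured so far:
compound 1 `COc1ccc(OCC(=O)Nc2cccc(NC(=O)c3ccc(N(C)C)cc3)c2)cc1F` — 652 nM
compound 2 `Cc1coc2cc(OCC(=O)Nc3cccc(NC(=O)c4ccc(N(C)C)cc4)c3)ccc2c1=O` — 2150 nM
compound 3 `CC(=O)Nc1cccc(NC(=O)COc2ccc3c(=O)ccoc3c2)c1` — 136 nM

In an assay on isolated protein for inhibition of Rho-associated protein kinase 2 (Homo sapiens), read by scintillation counting, radiometric assay and 33P incorporation, with a stated time of 40 min, in the presence of a further agent that is not named here (on this read-out lower numbers stand for stronger inhibition and higher numbers for weaker inhibition), compound 3 stands lowest of the three numbers; the gaps to compound 1 and to compound 2 both lie beyond the scatter. Going by the values given here, neither of those two differs from compound 3 in one place only, so no single-point step among the measured compounds is available.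

Compound 4 `CCCc1ccc(C(=O)Nc2cccc(NC(=O)COc3ccc4c(=O)ccoc4c3)c2)cc1` is not yet measured. It differs from compound 3 by 4-propylphenyl in place of methyl on a carbonyl carbon. The two measured compounds carrying an aryl carbonyl at that amide, compound 1 and compound 2, give higher numbers than compound 3, but each also differs in the ether part, so the expectation rests on little. A modest rise, toward weaker inhibition, is expected for compound 4 as the step of a 2.2-fold higher number from compound 3 to compound 4 (0.34 log units; beyond the scatter), within the scatter or slightly beyond it. Compound 4 is estimated at 300 nM, with a range from 80 nM to 1200 nM.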

Compound 4, half-maximal inhibitory concentration: 14 nM
The estimate for compound 4 lay 21-fold (1.33 log units) above the measured number; the whole stated range lies above it.
By their numbers in this assay, from the lowest: compound 4; then compound 3; then compound 1; then compound 2.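

Placing 4-propylphenyl in place of methyl on a carbonyl carbon gives a 9.7-fold lower number from compound 3 to compound 4 (0.99 log units; beyond the scatter) in this assay, a step beyond the scatter and the first single-place reading at this amide. This position therefore accepts a much larger aryl group with stronger inhibition, not merely without loss. No available measurement explains the step.

Open, on these data alone, is whether the ring or the propyl chain carries the change: an unsubstituted phenyl or a 4-pentylphenyl would separate the two. As far as these compounds go, a carboxylic acid at the end of that chain remains equally open.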